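The source may hold more compounds than are shown below. What is called first, only, known or untested is meant among the compounds shown, and "the series" means these compounds.

Working notes on the series. Compound 2 `CC1CCN(c2c(S(=O)(=O)c3ccccc3)cnc3ccc(Cl)cc23)CC1` stands lowest of the two numbers measured in an assay on isolated protein for displacement of a labelled ligand from metabotropic glutamate receptor 5 (Homo sapiens), with a stated time of 60 min, tested at 1 uM; a lower number here means less inhibition, a higher number more inhibition at the concentration tested (going by the name of the read-out): compound 2 gives 59%, while compound 1 `CC1CCN(c2c(S(=O)(=O)c3cc(Cl)cc(Cl)c3)cnc3ccc(Cl)cc23)CC1` gives 88%. Among the measured compounds shown here, the only measured step in this assay is a number 29 percentage points lower from compound 1 to compound 2 (beyond the scatter), so replacing the dichlorinated ring with the bare phenyl cost a modest amount of inhibition. Compound 3 `CC1CCN(c2c(S(=O)(=O)c3ccc(Cl)c(Cl)c3)cnc3ccc(Cl)cc23)CC1` is not yet measured; it differs from compound 2 by 3,4-dichlorophenyl in place of phenyl on a sulfonyl sulfur. The step from compound 1 to compound 2 bears on it directly, in reverse direction, since chlorines return to the ring on the sulfonyl sulfur, though in a different arrangement. On that basis a rise in this assay beyond the scatter is expected, roughly mirroring that step, namely a number 21 percentage points higher from compound 2 to compound 3 (beyond the scatter). For compound 3 the expected reading is 80%, with a range from 62% to 93%.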

Compound 3, a percentage reported as inhibition, at one concentration (the size of the read-out at that concentration, not a potency): 86%
Estimate against measurement, compound 3: 6 percentage points below, and the stated range covers the measured number.
By their numbers in this assay, from the lowest: compound 2; then compounds 3 and 1 (each within the scatter of the next).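

In this assay, the gain on the sulfonyl sulfur is not confined to the 3,5-dichlorophenyl group: 3,4-dichlorophenyl in place of phenyl gives a number 27 percentage points higher from compound 2 to compound 3 (beyond the scatter), so a second dichlorophenyl group also stands apart from phenyl. Exchanging one dichlorophenyl arrangement for the other gives a number 2 percentage points lower from compound 1 to compound 3 (within the scatter), so these two arrangements cannot be told apart in this assay at the single concentration tested. No measurement on hand accounts for this result.

Still open, from the compounds shown here alone, is whether a single chlorine on the ring is enough, or whether other groups at the same place, such as methoxy, nitrile or trifluoromethyl, behave like the chlorines. Also open, going by these compounds, is whether compound 1 and compound 3 would separate in a full concentration series.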